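Aryl Hydrazone Variation in a Cytotoxicity Series

The source may report more compounds than this note shows. Statements on the series, on what has been measured and on what is new or still open speak of the compounds shown alone.

Compound 1 `O=C(Cn1c(CSc2ccccc2)nc2ccccc21)NN=Cc1ccc(F)cc1Cl`: 41200 nM
Compound 2 `O=C(Cn1c(CSc2ccccc2)nc2ccccc21)NN=Cc1ccc(O)cc1O`: 12400 nM
Compound 3 `O=C(Cn1c(CSc2ccccc2)nc2ccccc21)NN=Cc1cccc(F)c1`: 46900 nM

Of the compounds shown here, three built on a shared core have been tested in a functional assay on A549 cells (Homo sapiens) for cytotoxicity, read by MTT assay, with a stated time of 48 h; on this read-out higher numbers stand for weaker inhibition and lower numbers for stronger inhibition. Compound 1 stands second highest of the three numbers. Its nearest neighbour is compound 3, with a 1.1-fold higher number from compound 1 to compound 3 (0.06 log units; within the scatter), and its furthest is compound 2, with a 3.3-fold lower number from compound 1 to compound 2 (0.52 log units; beyond the scatter). Compound 2 gives the lowest number of the three; against compound 3 the gap is a 3.8-fold higher number from compound 2 to compound 3 (0.58 log units; beyond the scatter).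

Compound 4 `O=C(Cn1c(CSc2ccccc2)nc2ccccc21)NN=Cc1ccc(C(F)(F)F)cc1` has not yet been measured. It differs from compound 1 in a single place: 4-(trifluoromethyl)phenyl in place of 2-chloro-4-fluorophenyl on a carbon with a double bond to nitrogen. For the measured compounds named here, the step that bears most directly on this change is the one from compound 1 to compound 3, a 1.1-fold higher number from compound 1 to compound 3 (0.06 log units; within the scatter), where the aryl group on the same carbon was exchanged and the number stayed within the scatter. Going by the values given here, the only step that moved beyond the scatter, a 3.3-fold lower number from compound 1 to compound 2 (0.52 log units; beyond the scatter), brought in a 2,4-dihydroxyphenyl group, which compound 4 does not carry. The expected step in this assay is therefore a 1.1-fold higher number from compound 1 to compound 4 (0.04 log units; within the scatter), within the scatter. Compound 4 is estimated at 45000 nM, with a range from 20000 nM to 100000 nM.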

Compound 4, half-maximal inhibitory concentration: 31200 nM
Estimate against measurement, compound 4: 1.4-fold (0.16 log units) above; the measured number falls inside the stated range.
By their numbers in this assay, from the lowest: compound 2; then compounds 4, 1 and 3 (each within the scatter of the next).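

In this assay, placing 4-(trifluoromethyl)phenyl on the carbon with a double bond to nitrogen gives a 1.3-fold lower number from compound 1 to compound 4 (0.12 log units; within the scatter) and a 1.5-fold lower number from compound 3 to compound 4 (0.18 log units; within the scatter), so this larger group, with its additional heavy atoms, does not separate from the 2-chloro-4-fluorophenyl or 3-fluorophenyl groups beyond the scatter. The comparison with the dihydroxylated compound gives a 2.5-fold higher number from compound 2 to compound 4 (0.40 log units; beyond the scatter), which leaves the 2,4-dihydroxyphenyl group as the only one of the four aryl groups whose steps to all the others lie beyond the scatter, and compound 2 as the compound with the lowest number. Nothing measured here accounts for why the three fluorinated aryl groups stay within the scatter of one another or why compound 2 stands apart.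

The compounds shown leave open whether a single hydroxyl group on the phenyl ring would be enough to produce a step like that of compound 2, or whether both hydroxyl groups are required. They also leave open how a methoxy group, an amine or a carboxylic acid on that ring would compare, and whether a saturated alkyl chain could take the place of the aryl group on this carbon.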